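From methyl to 4-fluorophenyl on a shared core

A few compounds are considered here, and "the series" means these few. Any claim that something is new, unique, unknown or untested is made for them only; others in the source may bear on it.

In a functional assay on HCT-116 cells (Homo sapiens) for cytotoxicity, read by MTT assay, with a stated time of 48 h, in the presence of a further agent that is not named here (a lower number here means that less compound is needed, a higher number that more compound is needed for the effect), compound 3 `Cc1cc(NNC(=O)Nc2cc(Cl)nc(Cl)c2)nc2c1c(C)nn2C` reads > 100000 nM, which is a limit of the assay and not a number. Compound 3 thus stands at the limit of > 100000 nM in this assay, at which 1 of the 3 values shown sits, here.

Two close relatives do give numbers. Compound 1 `Cc1nn(C)c2nc(NNC(=O)Nc3cc(Cl)nc(Cl)c3)cc(-c3ccco3)c12` gives 69200 nM and compound 2 `Cc1nn(C)c2nc(NNC(=O)Nc3cc(Cl)nc(Cl)c3)cc(-c3ccccc3)c12` gives 80000 nM in the same test, a swap of furan-2-yl for phenyl that amounts to a 1.2-fold higher number from compound 1 to compound 2 (0.06 log units; within the scatter) overall.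

Compound 4 `Cc1nn(C)c2nc(NNC(=O)Nc3cc(Cl)nc(Cl)c3)cc(-c3ccc(F)cc3)c12` differs from compound 3 by 4-fluorophenyl in place of methyl on an aromatic carbon in all, which is 4-fluorophenyl in place of methyl on an aromatic carbon. The nearest measured change runs the other way, with methyl replacing phenyl, and it comes to an at least 1.2-fold higher number from compound 2 to compound 3 (0.09 log units; that floor lies within the scatter) in size. Methyl replacing furan-2-yl gives an at least 1.4-fold higher number from compound 1 to compound 3 (0.15 log units; that floor lies within the scatter) in size. For the measured compounds named here, no measured compound carries the fluorine, so compound 4 is best read as a close match to compound 2 at 80000 nM in this test.

The expected change, an at least 1.3-fold lower number from compound 3 to compound 4 (0.12 log units; that floor lies within the scatter), is small and towards a lower number, with no clear move beyond the scatter. For compound 4 the estimated value is 75000 nM, with an expected range from 40000 nM to 100000 nM in this assay.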

Compound 4, half-maximal effective concentration: 25200 nM
Compound 4: the middle estimate sits 3.0-fold (0.47 log units) above what was measured; measured number below the stated range.
By their numbers in this assay, from the lowest: compound 4; then compounds 1 and 2 (each within the scatter of the next). At a limit, above all of these: compound 3.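

Fluoro in place of hydrogen on the phenyl group gives a 3.2-fold lower number from compound 2 to compound 4 (0.50 log units; beyond the scatter), the first change at this position in this assay to move a measured number beyond the scatter. Setting 4-fluorophenyl in place of furan-2-yl gives a 2.7-fold lower number from compound 1 to compound 4 (0.44 log units; beyond the scatter), so the choice of ring at this position can matter after all, although compound 4 is the only one that shows it. The step from methyl, an at least 3.9-fold lower number from compound 3 to compound 4 (0.59 log units; beyond the scatter), is only a floor, as compound 3 stands at a limit: the limit of > 100000 nM in this assay, at which 1 of the 4 values shown sits.

As far as these compounds go, what stays open is whether the fluorine is special or whether another group in its place, such as chloro, methoxy or an amine, would give a similar number. With only one fluorinated compound shown, the drop rests on a single pair of close relatives.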